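The compounds below may be only part of what the source reports. "The series", "measured", "known", "first", "only" and "open" are said of these compounds alone.

Measured in an assay on membranes from HEK293 cells for displacement of a labelled ligand from adenosine receptor A2b (Homo sapiens), read by scintillation counting, with a stated time of 30 min; a higher number here means a weaker inhibitor, a lower number a stronger inhibitor:

compound 1 `CC1=C(C(=O)OCc2ccccc2)C(c2ccco2)NC(=O)N1`: 887 nM
compound 2 `CC1=C(C(=O)OCC(C)C)C(c2ccoc2)NC(=O)N1`: 326 nM
compound 3 `CC1=C(C(=O)OCC(C)C)C(c2cccs2)NC(=O)N1`: 2130 nM

Compound 1 stands second highest of the three numbers in this assay: compound 3 sits higher, beyond the scatter, and compound 2 sits lower, also beyond the scatter. Compound 4 `CC1=C(C(=O)OCc2ccccc2)C(c2cccs2)NC(=O)N1` differs from compound 1 by thiophen-2-yl in place of furan-2-yl on a saturated ring carbon. Within the data shown here, the only measured step of this type is a 6.5-fold higher number from compound 2 to compound 3 (0.82 log units; beyond the scatter); there the furan was the 3-yl isomer and the rest of the molecule was not that of compound 1, so it bears on the present change only in part. Taken as a rough guide, it points to a higher number, and a step of about a 3.9-fold higher number from compound 1 to compound 4 (0.60 log units; beyond the scatter) is expected. Compound 4 is therefore estimated at 3500 nM, with a range of 1200 nM to 10000 nM.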

Compound 4, inhibition constant: 1920 nM
For compound 4 the middle estimate is 1.8-fold (0.26 log units) above the measured one; measured number inside the range.
By their numbers in this assay, from the lowest: compound 2; then compound 1; then compounds 4 and 3 (each within the scatter of the next).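

In this assay, thiophen-2-yl in place of furan-2-yl on the saturated ring carbon gives a 2.2-fold higher number from compound 1 to compound 4 (0.34 log units; beyond the scatter), so the direction seen with the furan-3-yl pair also holds with the phenyl-bearing chain. With thiophen-2-yl held constant, phenyl in place of isopropyl on the chain gives a 1.1-fold lower number from compound 3 to compound 4 (0.05 log units; within the scatter), so that chain change does not register on this background. No evidence on the cause of either result is available.

Open: whether the chain change stays as silent with furan-3-yl on the ring carbon, and how a plain phenyl or cyclohexyl there compares.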